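A few compounds are considered here, and "the series" means these few. Any claim that something is new, unique, unknown or untested is made for them only; others in the source may bear on it.

Compound 1 `Cc1oc(-c2c(F)cccc2F)nc1CN1CCC(C(=O)NCCCN2C[C@H](C)C[C@H](C)C2)CC1` gives 0.35 h. Compound 2 `CC[C@@H]1C[C@H](CC)CN(CCCNC(=O)C2CCN(Cc3nc(-c4c(F)cccc4F)oc3C)CC2)C1` gives 0.065 h. Compound 3 `Cc1cccc(Cl)c1-c1nc(CN2CCC(C(=O)NCCCN3CCC(C(C)C)CC3)CC2)c(C)o1` gives 0.0333 h.

In an ADME assay on microsomes from liver (Rattus norvegicus) for metabolic stability, read by LC-MS, using NADPH, at 37 degrees C (a lower number here means that the compound disappears faster, a higher number that the compound lasts longer), compound 1 stands highest of the three numbers, with compound 2 nearest and compound 3 furthest, both beyond the scatter. Going by the values given here, the only single-point step measured, a 5.4-fold lower number from compound 1 to compound 2 (0.73 log units; beyond the scatter), concerns the piperidine end of the chain and not the aryl group. Compound 4 `Cc1ccc(-c2nc(CN3CCC(C(=O)NCCCN4C[C@H](C)C[C@H](C)C4)CC3)c(C)o2)cc1C` differs from compound 1 by 3,4-dimethylphenyl in place of 2,6-difluorophenyl on an aromatic carbon. Among the compounds with values here, no measured step touches this position, so the expectation rests on nothing firmer than the spread seen among the three numbers. A modest fall is expected for compound 4, a 2.3-fold lower number from compound 1 to compound 4 (0.37 log units; beyond the scatter). Compound 4 is therefore estimated at 0.15 h, with a range from 0.05 h to 0.45 h.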

Compound 4, half-life: > 0.5 h
Compound 4: a limit, no number (the forecaster's own chance of this, stated with the estimate: 5%); middle value at least 3.3-fold (0.52 log units) away from the limit.
By their numbers in this assay, from the lowest: compounds 3 and 2 (each within the scatter of the next); then compound 1. At a limit, above all of these: compound 4.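

In this assay compound 4 gives > 0.5 h, which is a limit of the assay and not a number. The step is an at least 1.4-fold higher number from compound 1 to compound 4 (0.15 log units; that floor lies within the scatter), so at this aromatic carbon 3,4-dimethylphenyl keeps the number at least level with 2,6-difluorophenyl, and the two fluorines prove unnecessary for holding it. How much higher the number lies cannot be read from a limit: the limit of > 0.5 h in this assay, at which 1 of the 4 values shown sits.

Open, on these data alone, is whether an unsubstituted phenyl or a pyridyl group at this place would hold the number as well. Also open, as far as these compounds go, is whether 3,4-dimethylphenyl would behave the same way alongside the 3,5-diethylpiperidin-1-yl end of compound 2.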